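This account rests on a few compounds, and the source may have more. Where it says the series, first, only, none or still open, it means among the compounds named here.

Three compounds have been measured in a functional assay on HeLa cells (Homo sapiens) for cytotoxicity, read by MTT assay (on this read-out lower numbers stand for stronger inhibition and higher numbers for weaker inhibition), as follows:

Compound 1 `CC(=O)OCCO[C@H](CC=C(C)C)C1=CC(=O)c2c(O)ccc(O)c2C1=O`: 41500 nM
Compound 2 `CCCC(CC(=O)O[C@H](CC=C(C)C)C1=CC(=O)c2c(O)ccc(O)c2C1=O)OC(C)=O`: 51200 nM
Compound 3 `CCC(C)(O)CC(=O)O[C@H](CC=C(C)C)C1=CC(=O)c2c(O)ccc(O)c2C1=O`: 25200 nM

Compound 3 stands level with compound 1 within the scatter (a 1.6-fold lower number from compound 1 to compound 3 (0.22 log units; within the scatter)) and is separated from compound 2 by a modest margin (a 2.0-fold lower number from compound 2 to compound 3 (0.31 log units; beyond the scatter)).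

The next compound, compound 4 `CCC(O)(CC)CC(=O)O[C@H](CC=C(C)C)C1=CC(=O)c2c(O)ccc(O)c2C1=O`, differs from compound 3 by one small change (methyl in place of hydrogen on a saturated chain carbon, two bonds along the chain from an oxygen on a saturated carbon). Cut one bond further out, this reads methyl to ethyl, turning 1-hydroxy-1-methylpropyl into 1-ethyl-1-hydroxypropyl.

Among the measured compounds shown here, no measured step makes this exact change. For the measured compounds named here, the closest is the one between compound 2 and compound 3, which puts 1-hydroxy-1-methylpropyl in place of 1-acetoxybutyl. The step between compound 1 and compound 3 exchanges a larger part of the side chain, yet it stays within the scatter. Given the modest size of the largest step seen (a 2.0-fold lower number from compound 2 to compound 3 (0.31 log units; beyond the scatter)), the added methyl is expected to produce no step beyond the scatter in this assay (in either direction).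

The estimate amounts to a small expected shift (a 1.1-fold lower number from compound 3 to compound 4 (0.04 log units; within the scatter)). For compound 4 the expected value is 23000 nM (estimated range 12000 nM to 45000 nM).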

Compound 4, half-maximal inhibitory concentration: 52000 nM
The estimate for compound 4 lay 2.3-fold (0.35 log units) below the measured number, and the stated range ends below it.
By their numbers in this assay, from the lowest: compounds 3, 1, 2 and 4 (each within the scatter of the next, the first and the last beyond it).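

In this assay, the single methyl that turns 1-hydroxy-1-methylpropyl into 1-ethyl-1-hydroxypropyl gives a step beyond the scatter, though only a modest one: a 2.1-fold higher number from compound 3 to compound 4 (0.31 log units; beyond the scatter). Among the compounds shown here, this shows that even a change of one carbon at this saturated chain carbon can move the number, which the earlier steps, all exchanging larger parts of the side chain, could not show. Compound 4 nevertheless stands level with the other two compounds, with a 1.0-fold higher number from compound 2 to compound 4 (0.01 log units; within the scatter) and a 1.3-fold higher number from compound 1 to compound 4 (0.10 log units; within the scatter), so the separation seen between compound 2 and compound 3 does not hold for this new group, and no measurement at hand accounts for the step.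

From the compounds shown here alone, it remains open whether the number keeps rising as this group grows, which a longer chain such as 1-hydroxy-1-propylbutyl would test, or whether the step stops at the ethyl group. Also open, going by these compounds, is what the hydroxy group on this carbon contributes, which a methoxy group or an amine in its place would show, and whether the same step appears in cells other than HeLa.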